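This account rests on a few compounds, and the source may have more. Where it says the series, first, only, none or still open, it means among the compounds named here.

Of the compounds shown here, three that share one core have been tested in an ADME assay on MRC5 cells (Homo sapiens) for cytotoxicity, read by neutral red uptake; a higher number here means that more compound is tolerated, a lower number that less compound is tolerated. Compound 1 (`COc1ccc(CSc2nc3ccccc3c(=O)[nH]2)cc1`) gives > 64000 nM, which is a limit. Compound 2 (`O=c1[nH]c(SCc2ccccc2[N+](=O)[O-])nc2ccccc12`) gives > 64000 nM, also a limit. Compound 3 (`O=c1[nH]c(SCc2ccc([N+](=O)[O-])cc2)nc2ccccc12`) gives > 64000 nM, again only a limit, so it has no exact place on the scale. Going by the values given here, in fact, the series so far stands at the limit of > 64000 nM in this assay, at which 3 of the 3 values shown sit.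

Compound 4 (`O=c1[nH]c(SCc2ccc([N+](=O)[O-])cc2[N+](=O)[O-])nc2ccccc12`) differs from compound 3 by nitro in place of hydrogen on an aromatic carbon. The new nitro sits ortho to a large group and meta to the existing nitro group. The closest measured change is a step that the two limits leave unreadable from compound 1 to compound 3, and it gives no size to carry over. Nothing measured therefore points to a real shift in this assay. The expected change is an at least 1.2-fold lower number from compound 3 to compound 4 (0.10 log units; that floor lies within the scatter), which is estimated to stay within the scatter, with any movement expected toward less compound being tolerated. For compound 4 the estimated value is 50000 nM, with an expected range from 15000 nM to 100000 nM.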

Compound 4, half-maximal cytotoxic concentration: > 64000 nM
Compound 4: only a limit was reported; the forecaster's own chance of this, stated with the estimate: 60%; at least 1.2-fold (0.10 log units) between middle value and limit.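

Compound 4 reports only a limit, as do compound 2 and compound 3, so neither step to compound 4 can be read in this assay. The compounds shown leave open whether any change on the shared core moves this number, and the series still stands at one place: the limit of > 64000 nM in this assay, at which 4 of the 4 values shown sit.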